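The source may report more compounds than this note shows. Statements on the series, on what has been measured and on what is new or still open speak of the compounds shown alone.

Measured compounds in a functional assay on HepG2 cells (Homo sapiens) for inhibition, read by MTT assay, with a stated time of 72 h; on this read-out higher numbers stand for weaker inhibition and lower numbers for stronger inhibition:
- compound 1 `Cn1ccc2c(Oc3ccc(NC(=O)c4cn(-c5ccc(Br)cc5F)c5ccccc5c4=O)cc3F)ccnc21` gives 2510 nM
- compound 2 `O=C(Nc1ccc(Oc2ccnc3[nH]ccc23)c(F)c1)c1cn(-c2ccccc2)c2ccccc2c1=O` gives 760 nM
- compound 3 `O=C(Nc1ccc(Oc2ccnc3[nH]ccc23)c(F)c1)c1cn(-c2ccc(F)cc2)c2ccccc2c1=O` gives 270 nM

Compound 3 stands lowest of the three numbers in this assay. Its nearest neighbour is compound 2, and the move from the one to the other is a 2.8-fold lower number from compound 2 to compound 3 (0.45 log units; beyond the scatter), a change that lies beyond the scatter. Compound 1 stands furthest from compound 3.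

Compound 4 `O=C(Nc1ccc(Oc2ccnc3[nH]ccc23)c(F)c1)c1cn(-c2ccc(Br)cc2F)c2ccccc2c1=O` is not yet measured. It differs from compound 3 in one place: 4-bromo-2-fluorophenyl in place of 4-fluorophenyl on an aromatic nitrogen. Among the measured compounds shown here, only one measured step bears on the aryl group on that nitrogen, the step of a 2.8-fold lower number from compound 2 to compound 3 (0.45 log units; beyond the scatter), which shows that a fluoro on that ring can shift the number by a modest amount. For the measured compounds named here, compound 1 carries the same 4-bromo-2-fluorophenyl as compound 4 but on a different core, so its value cannot be separated into the two changes; it shows only that this group, with that core, gave a higher number than compounds 2 and 3. Compound 4 is therefore expected to give a modestly higher number than compound 3, a step of a 1.9-fold higher number from compound 3 to compound 4 (0.27 log units; within the scatter). The estimate for compound 4 in this assay is 500 nM, within a range of 150 nM to 1700 nM.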

Compound 4, half-maximal inhibitory concentration: 2200 nM
Compound 4: middle estimate off by 4.4-fold (0.64 log units), on the low side; the whole stated range lies below it.
By their numbers in this assay, from the lowest: compound 3; then compound 2; then compounds 4 and 1 (each within the scatter of the next).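

In this assay, among the compounds shown here, the aryl group on the aromatic nitrogen proves able to move the number in both directions: the single fluoro of compound 3 had lowered it, but 4-bromo-2-fluorophenyl gives an 8.1-fold higher number from compound 3 to compound 4 (0.91 log units; beyond the scatter) and, against the unsubstituted ring, a 2.9-fold higher number from compound 2 to compound 4 (0.46 log units; beyond the scatter), so the added halogens more than cancel the earlier gain. The methyl on the other aromatic nitrogen turns out to matter little with this aryl group, since a 1.1-fold lower number from compound 1 to compound 4 (0.06 log units; within the scatter) stays within the scatter, and the high value of compound 1 therefore goes with the aryl group it shares with compound 4 and not with that methyl. No measurement shown here explains why this aryl change raises the number.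

Because bromine and the second fluorine enter together, the compounds shown do not separate their contributions, and 4-bromophenyl and 2-fluorophenyl on that nitrogen would be needed to do so. On these data alone, it also remains open how this position would respond to a methoxy group, an amine or a nitrile in place of the bromine, and whether the steps seen here would hold with such groups.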